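The source may report more compounds than this note shows. Statements on the series, on what has been measured and on what is new or still open speak of the compounds shown alone.

For the measured compounds named here, compound 1 `COc1ccc([C@@H]2C/C(=N/OCc3cn(-c4ccc(O)cc4)nn3)c3cc(CC=C(C)C)c(OC)cc3O2)cc1` carries a 4-hydroxyphenyl on an aromatic nitrogen, and in a functional assay on HCT-116 cells (Homo sapiens) for inhibition, read by sulforhodamine B assay, with a stated time of 48 h, tested at 50 uM (on this read-out higher numbers stand for more inhibition of growth at the one concentration tested and lower numbers for less inhibition of growth), compound 1 gives 65% as the highest of the three numbers so far. Compound 2 `COc1ccc([C@@H]2C/C(=N/OCc3cn(-c4cccc(CO)c4)nn3)c3cc(CC=C(C)C)c(OC)cc3O2)cc1` has 3-(hydroxymethyl)phenyl in that place and gives 27% on the same core. Compound 3 `COc1ccc([C@@H]2C/C(=N/OCc3cn(-c4cc(OC)c(OC)c(OC)c4)nn3)c3cc(CC=C(C)C)c(OC)cc3O2)cc1` has 3,4,5-trimethoxyphenyl there and gives 29% on that core too. Compound 4 `COc1ccc([C@@H]2C/C(=N/OCc3cn(-c4ccc(NC(=O)c5ccccc5)cc4)nn3)c3cc(CC=C(C)C)c(OC)cc3O2)cc1` has not yet been measured. It differs from compound 1 by benzamido in place of hydroxy on an aromatic carbon with benzamido in place of hydroxy on an aromatic carbon, para to a large group. Going by the values given here, the closest evidence comes from changes to the same aromatic group: a number 38 percentage points lower from compound 1 to compound 2 (beyond the scatter) and a number 36 percentage points lower from compound 1 to compound 3 (beyond the scatter) are both large, while a number 2 percentage points higher from compound 2 to compound 3 (within the scatter) is the only small step. Neither large step brings in a benzamido, so they guide the expectation only loosely. A large downward step is therefore expected, with a number 32 percentage points lower from compound 1 to compound 4 (beyond the scatter) as the estimate for it. The expected value for compound 4 is 33% within an estimated range from 15% to 58% for repeat measurements.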

Compound 4, percent growth inhibition at one concentration: 8%
The estimate for compound 4 lay 25 percentage points above the measured number; measured number below the stated range.
By their numbers in this assay, from the lowest: compound 4; then compounds 2 and 3 (each within the scatter of the next); then compound 1.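

In this assay, benzamido in place of hydroxy gives a number 57 percentage points lower from compound 1 to compound 4 (beyond the scatter). Unlike the groups in compound 2 and compound 3, benzamido sits on the same aromatic carbon as the hydroxy, para to a large group, so a change at this one carbon is enough for a large fall, even though the two groups have equal counts of hydrogen-bond donors and acceptors. Nothing measured here explains this fall.

The compounds shown leave open whether the fall goes with the added six-membered aromatic ring, the amide link or simply the larger group of 9 heavy atoms. A simple amine or a small acetamido on that carbon would help separate these possibilities.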